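Swapping the aryl group: what to expect for compound 4

The source may hold more compounds than are shown below. What is called first, only, known or untested is meant among the compounds shown, and "the series" means these compounds.

Readings in a physicochemical assay for solubility, in phosphate buffer, measured as kinetic solubility, at pH 7.4 (on this read-out lower numbers stand for lower solubility and higher numbers for higher solubility), for three compounds
Compound 1 (`Cc1oc(-c2c(Cl)cccc2Cl)nc1CN1CCC(C(=O)NCCCN2C[C@H](C)C[C@H](C)C2)CC1`) gives > 77 ug/mL
Compound 2 (`Cc1oc(-c2c(Cl)cccc2C(F)(F)F)nc1CN1CCC(C(=O)NCCCN2C[C@H](C)C[C@H](C)C2)CC1`) gives 65.1 ug/mL
Compound 3 (`Cc1ccc(-c2nc(CN3CCC(C(=O)NCCCN4C[C@H](C)C[C@H](C)C4)CC3)c(C)o2)cc1`) gives > 69 ug/mL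

Compound 3 has only a limit (> 69 ug/mL) and not a number. Compound 1 likewise has only a limit (> 77 ug/mL) and not a number. Compound 4 (`COc1cccc(F)c1-c1nc(CN2CCC(C(=O)NCCCN3C[C@H](C)C[C@H](C)C3)CC2)c(C)o1`) carries 2-fluoro-6-methoxyphenyl in place of 4-methylphenyl on an aromatic carbon and is otherwise unchanged. Three measured swaps on this aryl group bear on it. Among the measured compounds shown here, they are the first (an at least 1.0-fold higher number from compound 2 to compound 3 (0.02 log units; that floor lies within the scatter)), the second (an at least 1.1-fold lower number from compound 1 to compound 2 (0.07 log units; that floor lies within the scatter)) and the third (a step that the two limits leave unreadable from compound 1 to compound 3), which has no readable size. Neither readable step leaves the scatter, so no step beyond the scatter is expected in this assay (a step that the limit leaves unreadable from compound 3 to compound 4). For compound 4 the estimated value is 70 ug/mL (expected range 45 ug/mL to 80 ug/mL).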

Compound 4, solubility: > 74 ug/mL
Compound 4 gave a limit, no number; the forecaster's own chance of this, stated with the estimate: 65%; middle value at least 1.0-fold (0.02 log units) away from the limit.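

In this assay compound 4 gives > 74 ug/mL, which is a limit and not a number. Among the compounds shown here, the one readable step is an at least 1.1-fold higher number from compound 2 to compound 4 (0.05 log units; that floor lies within the scatter). For the compounds shown here, the steps from compound 3 to compound 4 and from compound 1 to compound 4 cannot be read, so 2-fluoro-6-methoxyphenyl, the first group here with an oxygen and a fluorine, shows no step beyond the scatter at this position.

On these data alone, the true values of compound 1, compound 3 and compound 4 remain open. Also open, as far as these compounds go, is how an amine or a carboxylic acid on this aryl group would read.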